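The source may hold more compounds than are shown below. What is called first, only, known or untested is meant among the compounds shown, and "the series" means these compounds.

Three compounds of the series carry a number in a functional assay for inhibition of Vanilloid receptor (Rattus norvegicus); a higher number here means a weaker inhibitor, a lower number a stronger inhibitor. Compound 1 `CCCCOc1cc(C(C)(C)C)ccc1C/N=C(\S)NCc1ccc(NS(C)(=O)=O)cc1` gives 60 nM, compound 2 `CC(C)(C)COc1cc(C(C)(C)C)ccc1C/N=C(\S)NCc1ccc(NS(C)(=O)=O)cc1` gives 60 nM, and compound 3 `CCCCOc1cc(C(C)(C)C)ccc1C/N=C(\S)NCc1ccc(NS(C)(=O)=O)c(F)c1` gives 20 nM. Compound 3 holds the lowest number of the three: the step reads a 3.0-fold lower number from compound 1 to compound 3 (0.48 log units; beyond the scatter) for fluoro in place of hydrogen on an aromatic carbon, and compound 2 sits the same distance above it. The other measured step is no change at the digits printed from compound 1 to compound 2 (within the scatter), tert-butyl in place of propyl on a saturated chain carbon bound to an oxygen on an aromatic ring.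

Compound 4 `CC(C)(C)COc1cc(C(C)(C)C)ccc1C/N=C(\S)NCc1ccc(NS(C)(=O)=O)c(F)c1` awaits measurement in this assay. It differs from compound 3 in one place: tert-butyl in place of propyl on a saturated chain carbon bound to an oxygen on an aromatic ring. For the measured compounds named here, the only measured step that bears on this exchange is no change at the digits printed from compound 1 to compound 2 (within the scatter), the same exchange on the core lacking the fluoro; there the number did not move. Going by the values given here, no measured pair shows the fluoro and the tert-butyl together, so whether the two changes combine otherwise is not known from these numbers. The step expected from compound 3 to compound 4 in this assay is therefore no change at the digits printed from compound 3 to compound 4 (within the scatter), nothing beyond the scatter. Compound 4 is estimated at 20 nM, with a range of 8 nM to 50 nM.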

Compound 4, half-maximal inhibitory concentration: 66 nM
Compound 4: middle estimate off by 3.3-fold (0.52 log units), on the low side; the measured number lies above the stated range.
By their numbers in this assay, from the lowest: compound 3; then compounds 1, 2 and 4 (each within the scatter of the next).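

The exchange of propyl for tert-butyl on a saturated chain carbon bound to an oxygen on an aromatic ring, butoxy to neopentyloxy, now proves to depend on the core in this assay, with a 3.3-fold higher number from compound 3 to compound 4 (0.52 log units; beyond the scatter) where the fluoro is present, so the two readings of this change disagree: the same change on two cores in this assay, no change at the digits printed (within the scatter) from compound 1 to compound 2 and a 3.3-fold higher number (0.52 log units; beyond the scatter) from compound 3 to compound 4, 3.3-fold (0.52 log units) apart, beyond the scatter of two such steps

The fluoro shows the same dependence from its side, with a 1.1-fold higher number from compound 2 to compound 4 (0.04 log units; within the scatter) on the neopentyloxy core, so among these compounds its lower number appears only with butoxy: the same change on two cores in this assay, a 3.0-fold lower number (0.48 log units; beyond the scatter) from compound 1 to compound 3 and a 1.1-fold higher number (0.04 log units; within the scatter) from compound 2 to compound 4, 3.3-fold (0.52 log units) apart, beyond the scatter of two such steps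

For the compounds shown here, the two changes therefore do not add, and compound 3 at 20 nM stands alone as the one member that pairs fluoro with butoxy, while compounds 1, 2 and 4 remain within the scatter of one another.

With only butoxy and neopentyloxy shown, chain branching and chain length cannot be told apart, and an isobutoxy or ethoxy group on the fluoro core would bear on that. The compounds also leave open whether this dependence is particular to fluoro, a question that a chloro in the same place could address.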